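A few compounds are considered here, and "the series" means these few. Any claim that something is new, unique, unknown or untested is made for them only; others in the source may bear on it.

Of the compounds shown here, three with a shared core have been measured in a physicochemical assay for lipophilicity, read by HPLC, at pH 7.4; on this read-out lower numbers stand for lower lipophilicity and higher numbers for higher lipophilicity: compound 1 `CNCc1cn(S(=O)(=O)c2ccccn2)c(-c2cccnc2F)c1F` gives 0.44, compound 2 `CNCc1cn(S(=O)(=O)c2cccc(C)n2)c(-c2cccnc2F)c1F` gives 0.71, and compound 3 `CNCc1cn(S(=O)(=O)c2cccc(F)n2)c(-c2cccnc2F)c1F` gives 0.7. Compound 3 therefore lies within the scatter of both others. The next compound, compound 4 `CNCc1cn(S(=O)(=O)c2ccc(F)cn2)c(-c2cccnc2F)c1F`, has the same atoms as compound 3, joined differently: 5-fluoropyridin-2-yl in place of 6-fluoropyridin-2-yl on a sulfonyl sulfur. In words, this is 5-fluoropyridin-2-yl in place of 6-fluoropyridin-2-yl on a sulfonyl sulfur.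

For the measured compounds named here, no measured step makes this exact change, so the evidence is indirect. The measured compounds differ from one another in one place, and these differences gave a number 0.26 log units higher from compound 1 to compound 3 (within the scatter), then a number 0.27 log units higher from compound 1 to compound 2 (within the scatter), and finally a number 0.01 log units lower from compound 2 to compound 3 (within the scatter). With all of these inside the scatter, no shift beyond the scatter is expected in this assay, and the data favour no direction. The estimated step is no change at the digits printed from compound 3 to compound 4 (within the scatter). Compound 4 is expected at 0.7, within an estimated range from 0.4 to 1.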

Compound 4, distribution coefficient: 0.42
The estimate for compound 4 lay 0.28 log units above the measured number; the measured number falls inside the stated range.
By their numbers in this assay, from the lowest: compounds 4, 1, 3 and 2 (each within the scatter of the next).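

In this assay, 5-fluoropyridin-2-yl in place of 6-fluoropyridin-2-yl on a sulfonyl sulfur gave a number 0.28 log units lower from compound 3 to compound 4 (within the scatter), so an exchange that keeps the same atoms and only joins them differently also stays inside the scatter, as every earlier step did. The two further comparisons, a number 0.29 log units lower from compound 2 to compound 4 (within the scatter) and a number 0.02 log units lower from compound 1 to compound 4 (within the scatter), stay inside it too, so this read-out does not separate the four groups shown on the sulfonyl sulfur. Nothing shown gives a reason for these numbers.

Going by these compounds, whether an amine, a carboxylic acid or a longer alkyl chain in place of the fluoro of 5-fluoropyridin-2-yl would give a step beyond the scatter stays open. Changes elsewhere stay open as well, since all four compounds share the remainder of the core.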